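The compounds below may be only part of what the source reports. "The series", "measured", "known", "first", "only" and "open" are said of these compounds alone.

Compound 1 `COc1ccc(-c2nc3cc(F)ccc3s2)cc1`: 330 nM
Compound 2 `COc1ccc(-c2nc3cc(F)ccc3s2)cc1Br`: 420 nM

Both values come from a functional assay on MDA-MB-468 cells (Homo sapiens) for antiproliferative activity; a higher number here means a weaker inhibitor of growth, a lower number a stronger inhibitor of growth. Going by the values given here, compound 2, at 420 nM, cannot be told apart from compound 1, the only other compound measured so far. Compound 3 `COc1ccc(-c2nc3cc(F)ccc3s2)cc1I` remains to be tested. It carries iodo in place of bromo on an aromatic carbon, ortho to a methoxy group: iodo in place of bromo on an aromatic carbon. Among the compounds with values here, only one measured step bears on this swap, and it is an indirect guide, since it put bromo in place of hydrogen: a 1.3-fold higher number from compound 1 to compound 2 (0.10 log units; within the scatter). Within the data shown here, no iodo compound has a measured value yet, so the evidence is thin. Among the measured compounds shown here, with only that small step to go on, no change beyond the scatter is expected in this assay. The expected change is no change at the digits printed from compound 2 to compound 3 (within the scatter). For compound 3 the estimated value is 420 nM, with an expected range from 160 nM to 1100 nM.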

Compound 3, concentration for 50% growth inhibition: 360 nM
For compound 3 the middle estimate is 1.2-fold (0.07 log units) above the measured one; the measured number falls inside the stated range.
By their numbers in this assay, from the lowest: compounds 1, 3 and 2 (each within the scatter of the next).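

In this assay iodo in place of bromo gives a 1.2-fold lower number from compound 2 to compound 3 (0.07 log units; within the scatter) and iodo in place of hydrogen gives a 1.1-fold higher number from compound 1 to compound 3 (0.04 log units; within the scatter) on the same aromatic carbon, ortho to a methoxy group. The earlier pair set only bromo against hydrogen, and a second halogen at this carbon now also stays within the scatter of both neighbours, so hydrogen, bromo and iodo cannot be told apart here. No other measurement is available to explain this result.

Still open, from the compounds shown here alone, is whether this carbon accepts other kinds of group equally well, such as an amine, a carboxylic acid or a longer chain. Also open, going by these compounds, is whether these halogens would read alike on a core without the methoxy group.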